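Removing the Pyridine Methyl from Compound 1

The compounds below may be only part of what the source reports. "The series", "measured", "known", "first", "only" and "open" are said of these compounds alone.

Three measured compounds frame this step. In an assay for inhibition of kynurenine 3-monooxygenase (Homo sapiens), read by mass spectrometry, with a stated time of 1 h (on this read-out lower numbers stand for stronger inhibition and higher numbers for weaker inhibition), compound 1 `Cc1ccc([C@@H](C)Oc2cc3onc(CCC(=O)O)c3cc2Cl)nc1` gives 3.16 nM. Compound 2 `Cc1ccc([C@@H](C)Oc2cc3oc(=O)n(CCC(=O)O)c3cc2Cl)nc1` gives 3.16 nM in this assay, and compound 3 `O=C(O)CCn1c(=O)oc2cc(OCc3ccccn3)c(Cl)cc21` gives 3.16 nM. Compound 1 is therefore level with compounds 2 and 3 at the digits printed, with no difference beyond the scatter in either direction, its nearest neighbour being compound 2 and its furthest compound 3.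

The move from compound 1 to compound 4 `C[C@@H](Oc1cc2onc(CCC(=O)O)c2cc1Cl)c1ccccn1` is a single change: hydrogen in place of methyl on an aromatic carbon. For the measured compounds named here, no pair of measured compounds differs by exactly this change, so the size of the step cannot be read from a measured step. What the measured set does show is that compound 3, which carries a pyridin-2-yl without the methyl on a different core, gives 3.16 nM in this assay, the same figure as compound 1.

The step from compound 1 to compound 4 is expected to be a 1.3-fold higher number from compound 1 to compound 4 (0.10 log units; within the scatter), that is, no change beyond the scatter. Compound 4 is accordingly estimated at 4 nM in this assay, within a range of 1.5 nM to 12 nM.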

Compound 4, half-maximal inhibitory concentration: 5.01 nM
For compound 4 the middle estimate is 1.3-fold (0.10 log units) below the measured one; the range from low to high includes it.
By their numbers in this assay, from the lowest: compounds 1, 2, 3 and 4 (each within the scatter of the next).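

In this assay, for the compounds shown here, the change from 5-methylpyridin-2-yl to pyridin-2-yl now has a measured size on the core of compound 1: the step is a 1.6-fold higher number from compound 1 to compound 4 (0.20 log units; within the scatter) and so gives the first direct reading at this position. The earlier compounds shown here held no pair differing by this change alone, whereas here the methyl on this aromatic carbon, two atoms from the ring nitrogen, is replaced by hydrogen with the rest of the structure unchanged, and the number stays within the scatter. Nothing shown here gives a reason for the size of this step.

From the compounds shown here alone, whether a larger group on the same carbon, such as an ethyl, a methoxy or a trifluoromethyl, would also leave the number within the scatter remains open. So does whether removing the methyl from compound 2 would give a step of similar size on that core.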